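Hydroxy on the ethoxy chain of compound 1

The source may hold more compounds than are shown below. What is called first, only, known or untested is meant among the compounds shown, and "the series" means these compounds.

Compound 1 `CCO/N=C/c1c(N)ncnc1Oc1ccc2[nH]c(C)cc2c1F` is the most potent of the three compounds measured in a functional assay on A-375 cells (Homo sapiens) for antiproliferative activity (a lower number here means a stronger inhibitor, a higher number a weaker inhibitor), where compound 1 gives 27 nM. Compound 3 `CO/N=C/c1c(N)ncnc1Oc1ccc2[nH]ccc2c1F` stands nearest, with 492 nM, and compound 2 `CO/N=C/c1c(N)ncnc1Oc1ccc2[nH]ccc2c1` furthest, with 783 nM; both gaps to compound 1 lie beyond the scatter. Going by the values given here, the only step measured within the set, a 1.6-fold lower number from compound 2 to compound 3 (0.20 log units; within the scatter), concerns fluoro in place of hydrogen on an aromatic carbon and leaves the ethoxy chain untouched, so it does not bear on the change considered here.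

Compound 4 `Cc1cc2c(F)c(Oc3ncnc(N)c3/C=N/OCCO)ccc2[nH]1` differs from compound 1 by hydroxy in place of hydrogen on a saturated chain carbon, two bonds along the chain from an oxygen, that is, ethoxy to 2-hydroxyethoxy. Among the compounds with values here, no measured pair in the set varies this chain, and the data give no basis for a shift in either direction. The working expectation is therefore a step no larger than the scatter: compound 4 is expected to give 35 nM, within a range of 12 nM to 110 nM. The expected step is a 1.3-fold higher number from compound 1 to compound 4 (0.11 log units; within the scatter), judged to stay within the scatter.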

Compound 4, half-maximal inhibitory concentration: 372 nM
Beside the measured number, compound 4's estimate is 11-fold (1.03 log units) below it, and the stated range ends below it.
By their numbers in this assay, from the lowest: compound 1; then compounds 4, 3 and 2 (each within the scatter of the next, the first and the last beyond it).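

Going by these compounds alone, the ethoxy chain proves to be a sensitive place in this assay: ethoxy to 2-hydroxyethoxy gives a 14-fold higher number from compound 1 to compound 4 (1.14 log units; beyond the scatter), a large step, whereas the only earlier step, a 1.6-fold lower number from compound 2 to compound 3 (0.20 log units; within the scatter), stayed within the scatter and concerned a different place. A single hydroxy on this chain is thus enough to remove most of the potency of the core of compound 1. No measurement shown accounts for the size of this step.

From the compounds shown here alone, it remains open whether the loss is specific to the free hydroxy, or whether an amine, a carboxylic acid or a methyl ether at the same chain carbon would behave alike. A longer chain such as propoxy, with or without a terminal hydroxy, would show whether the chain itself tolerates extension.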